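Methoxy in Place of Phenyl: An Expected Step

The compounds below may be only part of what the source reports. "The series", "measured", "known", "first", "only" and "open" are said of these compounds alone.

Compound 1 `CCCN(CC[C@H]1CC[C@H](NC(=O)/C=C/c2ccccc2Cl)CC1)[C@H]1CCc2nc(N)sc2C1` and compound 2 `CCCN(CC[C@H]1CC[C@H](NS(=O)(=O)c2ccc(-c3ccccc3)cc2)CC1)[C@H]1CCc2nc(N)sc2C1` share one core and differ in the group on the ring nitrogen. In an assay on brain for displacement of a labelled ligand from D(3) dopamine receptor (Rattus norvegicus) (on this read-out higher numbers stand for weaker inhibition and lower numbers for stronger inhibition), compound 1 gives 1.2 nM, while compound 2 gives 41 nM, the higher of the two numbers, a gap beyond the scatter. Compound 3 `CCCN(CC[C@H]1CC[C@H](NS(=O)(=O)c2ccc(OC)cc2)CC1)[C@H]1CCc2nc(N)sc2C1` differs from compound 2 by methoxy in place of phenyl on an aromatic carbon. Going by the values given here, no measured pair shows this change, so its direction is untested. The step is expected to be a 2.0-fold higher number from compound 2 to compound 3 (0.29 log units; within the scatter) in this assay, toward weaker binding. Compound 3 is estimated at 80 nM, within 20 nM to 300 nM.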

Compound 3, inhibition constant: 0.78 nM
The estimate for compound 3 lay 100-fold (2.01 log units) above the measured number; the whole stated range lies above it.
By their numbers in this assay, from the lowest: compounds 3 and 1 (each within the scatter of the next); then compound 2.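

In this assay, 4-methoxyphenyl in place of 4-phenylphenyl gives a 53-fold lower number from compound 2 to compound 3 (1.72 log units; beyond the scatter), which shows that the group at this position can shift binding strongly on the sulfonyl side. Replacing (2-(2-chlorophenyl)ethenyl)carbonyl on the amine nitrogen with (4-methoxyphenyl)sulfonyl gives a 1.5-fold lower number from compound 1 to compound 3 (0.19 log units; within the scatter), so these two groups cannot be told apart here. No measurement at hand accounts for the large step.

As far as these compounds go, it remains open whether a hydroxyl, a methyl or a chlorine at this position would give a number like that of compound 3 0.78 nM or like that of compound 2 41 nM. Also open, from the compounds shown here alone, is whether an ethoxy or a longer alkoxy chain would hold the number of compound 3.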